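The compounds below may be only part of what the source reports. "The series", "measured", "known", "first", "only" and "open" are said of these compounds alone.

Measured so far in an ADME assay on MT4 cells (Homo sapiens) for cytotoxicity; a higher number here means that more compound is tolerated, a lower number that less compound is tolerated:
compound 1 `O=c1[nH]c2ccc(Cl)cc2n1Cc1cc(F)cc(F)c1`: > 424000 nM (a limit)
compound 2 `CC(=O)n1c(=O)n(Cc2cc(F)cc(F)c2)c2cc(Cl)ccc21`: 40400 nM

Compound 1 stands at the limit of > 424000 nM in this assay, at which 1 of the 2 values shown sits. That entry is a limit and not a number, so any step away from compound 1 can only be read approximately.

Compound 3 `Cc1ccc2[nH]c(=O)n(Cc3cc(F)cc(F)c3)c2c1` differs from compound 1 by methyl in place of chloro on an aromatic carbon. Among the compounds with values here, the only measured step is an at least 10-fold lower number from compound 1 to compound 2 (1.02 log units; beyond the scatter). It is large, but it is acetyl in place of hydrogen on an aromatic nitrogen, so it bears on the present change only loosely. It shows that the number in this assay can move within this small series. Within the data shown here, no step with a change on the aromatic carbon has been measured, so neither its size nor its direction can be carried over. No step beyond the scatter is therefore expected, and the assay may again report only a limit. The expected step is an at least 1.2-fold lower number from compound 1 to compound 3 (0.08 log units; that floor lies within the scatter). For compound 3 the estimated value is 350000 nM, with an expected range of 80000 nM to 460000 nM.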

Compound 3, half-maximal cytotoxic concentration: 73000 nM
Beside the measured number, compound 3's estimate is 4.8-fold (0.68 log units) above it, and the stated range ends above it.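

In this assay, methyl in place of chloro on an aromatic carbon gives an at least 5.8-fold lower number from compound 1 to compound 3 (0.76 log units; beyond the scatter). Within the data shown here, the only earlier step lay on an aromatic nitrogen, so this result adds a second place on the shared core where the number moves beyond the scatter, here with the hydrogen on that nitrogen left in place and with one heavy atom exchanged for one heavy atom. Compound 1 carries a limit and not a number, so the step gives only a floor, and its full size stays unknown because of that entry: the limit of > 424000 nM in this assay, at which 1 of the 3 values shown sits.

From the compounds shown here alone, it remains open whether the lower number belongs to methyl itself or whether other groups on this aromatic carbon, such as hydrogen, methoxy, an amine or a carboxylic acid, would stay at the level of compound 1 or fall towards that of compound 3. Also open, going by these compounds, is whether acetyl on the aromatic nitrogen and methyl on the aromatic carbon would together give a step different from either change alone.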